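Compound 1: From Acetyl to 1-Hydroxyethyl

This account rests on a few compounds, and the source may have more. Where it says the series, first, only, none or still open, it means among the compounds named here.

In a functional assay (aorta) with Oryctolagus cuniculus as the target (a lower number here means tighter binding, a higher number weaker binding), compound 1 `COc1cc(C(C)=O)ccc1OCCCN1CCC(C(c2ccc(F)cc2)c2ccc(F)cc2)CC1` stands at 1.59 nM and holds the lowest number of the three measured compounds. Compound 2 `COc1cc(C(C)=O)ccc1OCCCN1CCC(Cc2ccc(F)cc2)CC1` gives 20 nM and compound 3 `COc1cc(C(C)=O)ccc1OCCCN1CCC(C(N)(c2ccc(F)cc2)c2ccc(F)cc2)CC1` gives 31.6 nM in this assay under the same conditions. Both steps are large and beyond the scatter: a 13-fold higher number from compound 1 to compound 2 (1.10 log units; beyond the scatter) when hydrogen replaces 4-fluorophenyl on a saturated chain carbon, and a 20-fold higher number from compound 1 to compound 3 (1.30 log units; beyond the scatter) when amino replaces hydrogen on that carbon.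

The change to compound 4 `COc1cc(C(C)O)ccc1OCCCN1CCC(C(c2ccc(F)cc2)c2ccc(F)cc2)CC1` is of another kind. The difference is 1-hydroxyethyl in place of acetyl on an aromatic carbon and amounts to 1-hydroxyethyl in place of acetyl on an aromatic carbon. Among the compounds with values here, neither measured step touches the acetyl, and no measured compound shows what a change at that group does. These steps therefore set no size for this one and show only how far the numbers have moved among these compounds. A small rise in the number, perhaps none beyond the scatter, is expected, with the direction resting on judgement alone. The estimate amounts to a 1.9-fold higher number from compound 1 to compound 4 (0.28 log units; within the scatter) as an expected step. The estimate for compound 4 is 3 nM with an expected range from 1 nM up to 10 nM as the likely bounds.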

Compound 4, dissociation constant: 10 nM
Estimate against measurement, compound 4: 3.3-fold (0.52 log units) below; measured number inside the range.
By their numbers in this assay, from the lowest: compound 1; then compounds 4, 2 and 3 (each within the scatter of the next, the first and the last beyond it).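

In this assay the acetyl position proves responsive: 1-hydroxyethyl in place of acetyl, on an aromatic carbon meta to a methoxy group and para to a large group, gives a 6.3-fold higher number from compound 1 to compound 4 (0.80 log units; beyond the scatter) and so lies beyond the scatter. Within the data shown here, this is the first measured sign that the molecule's number depends on this group as well as on the saturated chain carbon altered in compound 2 and compound 3. The two groups have the same heavy atoms, so the step comes with a swap that keeps their count while removing a double bond outside aromatic rings and adding a hydrogen-bond donor, and no available evidence links the step to either difference or otherwise explains it.

The compounds shown leave open how other groups at this position would compare, such as a carboxylic acid, an amine, or a longer chain like propanoyl. They also leave open whether the same swap would give a step of similar size on the core of compound 2 or compound 3, where the saturated chain carbon carries different groups.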